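Methyl for phenyl on the saturated ring carbon

The compounds below may be only part of what the source reports. "The series", "measured", "known", "first", "only" and "open" are said of these compounds alone.

Measured so far in a functional assay on the whole organism (strain albino) for inhibition, with Rattus norvegicus as the target, read by paw edema, with stated times of 30 min and 4 h, at a dose of 25 mg/kg by the intraperitoneal route; a higher number here means more inhibition at the dose given (going by the name of the read-out), a lower number less inhibition:
compound 1, `COc1ccc(C2=NN(C(=O)NS(=O)(=O)c3ccc(Cl)cc3)CC2C)c(OC)c1`, gives 18.8%
compound 2, `COc1ccc(C2=NN(C(=O)NS(=O)(=O)c3ccc(C)cc3)CC2c2ccccc2)c(OC)c1`, gives 7.21%

Compound 2 stands lowest of the two numbers in this assay; compound 1 lies higher by more than the usual scatter. For the measured compounds named here, no pair differing in a single place has been measured, so no step is known. Compound 3, `COc1ccc(C2=NN(C(=O)NS(=O)(=O)c3ccc(C)cc3)CC2C)c(OC)c1`, differs from compound 2 in one place: methyl in place of phenyl on a saturated ring carbon. Compound 3 carries the methyl of compound 1, so a rise toward the value of compound 1 is expected, estimated at a number 7.8 percentage points higher from compound 2 to compound 3 (within the scatter) in this assay. For compound 3 the expected value is 15%, between 5% and 27%.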

Compound 3, a percentage reported as inhibition, in the whole organism at one dose (the size of the read-out at that dose, not a potency): 25.1%
Estimate against measurement, compound 3: 10.1 percentage points below; low and high end bracket the measured number.
By their numbers in this assay, from the lowest: compound 2; then compounds 1 and 3 (each within the scatter of the next).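

Methyl in place of phenyl on a saturated ring carbon gives a number 17.9 percentage points higher from compound 2 to compound 3 (beyond the scatter) in this assay, the first readable step at this position, and it shows that the read-out at this dose responds to the change. With methyl on that ring carbon, methyl in place of chloro on an aromatic carbon gives a number 6.3 percentage points higher from compound 1 to compound 3 (within the scatter) and does not separate the two compounds.

As far as these compounds go, whether an ethyl group or an amine on the saturated ring carbon would stand with methyl or with phenyl stays open. Nothing available explains either step.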